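The compounds below may be only part of what the source reports. "The series", "measured", "known", "first", "only" and "open" are said of these compounds alone.

Three compounds share one core, differing only at its edges. Compound 1 `Cc1ccc(-c2nc(N)c3cc(Cc4ccccc4)sc3n2)o1` carries a methyl-bearing furan; in a functional assay on CHO-K1 cells for antagonist activity at adenosine receptor A1 (Homo sapiens), read by a beta-galactosidase reporter and cAMP accumulation, with stated times of 15 min and 6 h (on this read-out higher numbers stand for weaker inhibition and lower numbers for stronger inhibition), compound 1 gives 298 nM. Compound 2 `COc1ccccc1Cc1cc2c(N)nc(-c3ccc(C)o3)nc2s1` adds a methoxy group, and in this assay compound 2 gives 122 nM, a step of a 2.4-fold lower number from compound 1 to compound 2 (0.39 log units; beyond the scatter). Compound 3 `N#Cc1ccc(-c2nc(N)c3cc(Cc4ccccc4)sc3n2)o1` swaps the methyl on the furan for a cyano group, and in this assay compound 3 gives 3160 nM, the highest of the three numbers, reached by a step of an 11-fold higher number from compound 1 to compound 3 (1.03 log units; beyond the scatter).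

Compound 4 `Nc1nc(-c2ncco2)nc2sc(Cc3ccccc3)cc12` takes the next step: 1,3-oxazol-2-yl in place of 5-cyanofuran-2-yl on an aromatic carbon, on an aromatic carbon of a six-membered aromatic ring with two nitrogens, between two ring nitrogen atoms. For the measured compounds named here, the one measured step that bears on this is the large rise from compound 1 to compound 3, brought by the cyano group; removing that group should undo much of it, while the move from furan to oxazole has no precedent here. The number is therefore expected to fall, by roughly a 6.3-fold lower number from compound 3 to compound 4 (0.80 log units; beyond the scatter), landing for compound 4 at an estimated 500 nM, within 150 nM to 2000 nM.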

Compound 4, inhibition constant: 310 nM
Estimate against measurement, compound 4: 1.6-fold (0.21 log units) above; low and high end bracket the measured number.
By their numbers in this assay, from the lowest: compound 2; then compounds 1 and 4 (each within the scatter of the next); then compound 3.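

In this assay, putting 1,3-oxazol-2-yl in place of 5-cyanofuran-2-yl gives a 10-fold lower number from compound 3 to compound 4 (1.01 log units; beyond the scatter), so the high number of compound 3 does not belong to the shared core or to every five-membered aromatic ring at this position. Set against the methyl-bearing furan, the same change gives a 1.0-fold higher number from compound 1 to compound 4 (0.02 log units; within the scatter), which means that 5-methylfuran-2-yl and 1,3-oxazol-2-yl cannot be told apart here on this read-out. Nothing shown explains why these steps have the sizes they do.

Still open, on these data alone, is what an amine or a carboxylic acid would do on the furan, where the methyl and the nitrile sit. Also open, as far as these compounds go, is whether the methoxy group of compound 2 would lower the number in the same way on the core of compound 4.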